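The compounds below may be only part of what the source reports. "The series", "measured", "known", "first", "only" and "open" are said of these compounds alone.

Measured in an ADME assay (Rattus norvegicus, strain Wistar Han) for metabolic stability; a lower number here means that the compound disappears faster, a higher number that the compound lasts longer:
- compound 1 `CCn1c(-c2cnc(C)nc2)nc2c(N[C@H]3CCN(C(=O)N4CC(OC)C4)C3)ncnc21`: 4 h
- compound 2 `CCn1c(-c2cnc(C)nc2)nc2c(N[C@H]3CCN(C(=O)C4CCOC4)C3)ncnc21`: 0.6 h
- compound 3 `CCC(=O)N1CC[C@H](Nc2ncnc3c2nc(-c2cnc(C)nc2)n3CC)C1`: 1.5 h

Compound 3 stands second highest of the three, at 1.5 h. Compound 4 `CCn1c(-c2cnc(C)nc2)nc2c(N[C@H]3CCN(C(=O)C4CC4)C3)ncnc21` brings (cyclopropyl in place of ethyl on a carbonyl carbon), cyclopropyl in place of ethyl on a carbonyl carbon. Within the data shown here, no measured step makes this exact exchange. The nearest guides are the three changes on that same carbonyl carbon: a 6.7-fold lower number from compound 1 to compound 2 (0.82 log units; beyond the scatter), a 2.7-fold lower number from compound 1 to compound 3 (0.43 log units; beyond the scatter) and a 2.5-fold higher number from compound 2 to compound 3 (0.40 log units; beyond the scatter). All are modest, though beyond the scatter, and each exchanges groups less alike than ethyl and cyclopropyl. In this assay the expected change is therefore none beyond the scatter, with no firm direction: a 1.1-fold higher number from compound 3 to compound 4 (0.03 log units; within the scatter). For compound 4 the estimated value is 1.6 h, with an expected range of 0.8 h to 3.2 h.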

Compound 4, half-life: 2.7 h
Beside the measured number, compound 4's estimate is 1.7-fold (0.23 log units) below it, within the range that was stated.
By their numbers in this assay, from the lowest: compound 2; then compounds 3, 4 and 1 (each within the scatter of the next, the first and the last beyond it).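

In this assay, cyclopropyl on this carbonyl carbon stays within the scatter of ethyl (a 1.8-fold higher number from compound 3 to compound 4 (0.26 log units; within the scatter)) and of 3-methoxyazetidin-1-yl (a 1.5-fold lower number from compound 1 to compound 4 (0.17 log units; within the scatter)). Oxolan-3-yl alone stands apart from cyclopropyl (a 4.5-fold higher number from compound 2 to compound 4 (0.65 log units; beyond the scatter)), so among these four compounds, the oxygen-bearing oxolane ring, not ring size or the presence of a ring as such, marks the one clear separation. No supporting data explain these steps.

Open, going by these compounds, is whether a cyclobutyl ring, a longer alkyl chain or a dimethylamino group on the same carbonyl carbon would group with cyclopropyl or with oxolan-3-yl.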